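The source may hold more compounds than are shown below. What is called first, only, known or untested is meant among the compounds shown, and "the series" means these compounds.

Working notes on the series in an assay on isolated protein for binding affinity to Leucine-rich repeat serine/threonine-protein kinase 2 (Homo sapiens), read by TR-FRET and LanthaScreen, with a stated time of 2 h; a lower number here means a stronger inhibitor, a higher number a weaker inhibitor.

Compound 1, `CN(C)c1c(C#N)c2c(N)ncnc2n1C`, gives 111 nM in this assay. Among the three numbers in hand it is the second highest; compound 2, `C[C@@H]1CCCN1c1cc2c(N)ncnc2n1C`, gives 164 nM, and the two values sit within the scatter of each other. Compound 3, `Cc1cn(C)nc1Nc1cc2c(c(N)n1)c(C#N)c(N1CCC[C@H]1C)n2C`, gives 63 nM, again within the scatter of compound 1, so none of the three can be ordered against the others.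

Compound 4, `C[C@H]1CCCN1c1c(C#N)c2c(N)ncnc2n1C`, has not yet been measured in this assay. It differs from compound 1 in one place: 2-methylpyrrolidin-1-yl in place of dimethylamino on an aromatic carbon. Among the measured compounds shown here, no measured pair isolates this change. Compound 2 also carries a 2-methylpyrrolidin-1-yl group on its core, though without the cyano group, and compound 3 carries both groups together with a further substituent; both sit within the scatter of compound 1.

On that basis no step beyond the scatter is expected for compound 4, with the estimate leaning slightly toward a lower number because compound 3 gives 63 nM. Compound 4 is expected to give about 65 nM in this assay, between 22 nM and 190 nM. The expected step from compound 1 to compound 4 is a 1.7-fold lower number from compound 1 to compound 4 (0.23 log units; within the scatter).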

Compound 4, inhibition constant: 136 nM
The estimate for compound 4 lay 2.1-fold (0.32 log units) below the measured number, within the range that was stated.
By their numbers in this assay, from the lowest: compounds 3, 1, 4 and 2 (each within the scatter of the next, the first and the last beyond it).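

In this assay, among the compounds shown here, 2-methylpyrrolidin-1-yl in place of dimethylamino gives a 1.2-fold higher number from compound 1 to compound 4 (0.09 log units; within the scatter), and this is the first pair that isolates this change. At this aromatic carbon, next to the ring nitrogen and next to the ring atom that bears a cyano group, going from 3 to 6 heavy atoms, with one five-membered non-aromatic ring and 1 defined stereocentre added, therefore produces no step beyond the scatter. Nothing in hand accounts for the two groups reading alike.

Going by these compounds, whether a plain pyrrolidin-1-yl, a morpholin-4-yl ring or a longer chain such as diethylamino would also stay within the scatter at this position remains open, as does the result for the mirror-image form of the 2-methylpyrrolidin-1-yl group. For the compounds shown here, also open is whether the same exchange would read the same way on the shared core with a hydrogen in place of the cyano group, since no single-change pair covers that case.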